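A few compounds are considered here, and "the series" means these few. Any claim that something is new, unique, unknown or untested is made for them only; others in the source may bear on it.

Within the data shown here, compound 3 `CCc1sc(CCc2cc(OCC(C)(C)C)cc(NCc3cc(Cl)cc(NC(=O)OC(C)C)c3)n2)nc1C` gives 55 nM in an assay on cells for binding affinity to Neuropeptide Y receptor type 1 (Homo sapiens) (a higher number here means a weaker inhibitor, a lower number a stronger inhibitor), the highest of the three numbers measured so far: compound 2 `CCc1sc(CCc2cc(OC(C)C)cc(NCc3cc(Cl)cc(NC(=O)OC(C)C)c3)n2)nc1C` gives 12 nM in this assay, and compound 1 `CC/C=C\CCOc1cc(CCc2nc(C)c(CC)s2)nc(NCc2cc(Cl)cc(NC(=O)OC(C)C)c2)c1` gives 4.7 nM. The steps leading into compound 3 run a 4.6-fold higher number from compound 2 to compound 3 (0.66 log units; beyond the scatter) and a 12-fold higher number from compound 1 to compound 3 (1.07 log units; beyond the scatter), while between the other two the step is a 2.6-fold higher number from compound 1 to compound 2 (0.41 log units; beyond the scatter).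

Compound 4 `CCc1sc(CCc2cc(OCCCc3ccccc3)cc(NCc3cc(Cl)cc(NC(=O)OC(C)C)c3)n2)nc1C` differs from compound 3 by phenethyl in place of tert-butyl on a saturated chain carbon bound to an oxygen on an aromatic ring. The two steps that bear on this change are those into compound 3: the unbranched hex-3-en-1-yl chain of compound 1 and the isopropyl of compound 2 both gave lower numbers than the neopentyl of compound 3, and the 3-phenylpropoxy chain of compound 4, like the chain of compound 1, is unbranched at the carbon bound to the oxygen. One therefore expects the number to fall again in this assay, by an amount estimated as a 4.6-fold lower number from compound 3 to compound 4 (0.66 log units; beyond the scatter). Compound 4 is accordingly expected to give about 12 nM in this assay, within a range of 3 nM to 45 nM.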

Compound 4, half-maximal inhibitory concentration: 20 nM
Compound 4: middle estimate off by 1.7-fold (0.22 log units), on the low side, within the range that was stated.
By their numbers in this assay, from the lowest: compound 1; then compounds 2 and 4 (each within the scatter of the next); then compound 3.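

In this assay, a six-membered aromatic ring at the end of the chain is accepted at this position: neopentyl gives way to 3-phenylpropyl with a fall in the number (a 2.8-fold lower number from compound 3 to compound 4 (0.44 log units; beyond the scatter)), so a chain carrying more heavy atoms need not cost affinity. Set against isopropyl, the same chain cannot be told apart (a 1.7-fold higher number from compound 2 to compound 4 (0.22 log units; within the scatter)), while the hex-3-en-1-yl chain keeps a lead beyond the scatter (a 4.3-fold higher number from compound 1 to compound 4 (0.63 log units; beyond the scatter)), so an unbranched start to the chain does not by itself match compound 1. Nothing measured here accounts for why these chains fall in this order.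

From the compounds shown here alone, it remains open whether a saturated hexyl chain would hold the number of compound 1. Equally open, going by these compounds, is how an amine or a carboxylic acid at the end of the 3-phenylpropyl chain would fare.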